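Inversion of two ring stereocentres in an iminosugar acid

The source may hold more compounds than are shown below. What is called first, only, known or untested is meant among the compounds shown, and "the series" means these compounds.

The measured compounds and their inhibition in an assay for inhibition of alpha-N-acetylgalactosaminidase (Gallus gallus), tested at 1000 uM; on this read-out lower numbers stand for less inhibition and higher numbers for more inhibition at the one concentration tested (going by the name of the read-out):
compound 1 `O=C(O)[C@H]1NC[C@@H](O)[C@H](O)[C@H]1O`, 4.2%
compound 2 `O=C(O)[C@H]1NC[C@@H](O)[C@H](O)[C@@H]1O`, 11%
compound 3 `O=C(O)[C@@H]1NC[C@H](O)[C@@H](O)[C@@H]1O`, 3.4%

All three compounds share the same atoms and bonds and differ only in the configuration drawn at their saturated ring carbons. Among the three numbers compound 1 is the second highest; its nearest neighbour is compound 3, reached by a number 0.8 percentage points lower from compound 1 to compound 3 (within the scatter), and its furthest is compound 2, reached by a number 6.8 percentage points higher from compound 1 to compound 2 (within the scatter). The remaining pair gives a number 7.6 percentage points lower from compound 2 to compound 3 (within the scatter). Every measured step therefore stays inside the usual scatter, whether one stereocentre is inverted (the fact that compounds 1 and 2 differ only in the configuration as drawn), all four are inverted (the fact that compounds 1 and 3 differ only in the configuration as drawn), or three are inverted (the fact that compounds 2 and 3 differ only in the configuration as drawn).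

Compound 4 `O=C(O)[C@@H]1NC[C@H](O)[C@H](O)[C@H]1O` is the next member of the set. Compared with compound 1, (the two compounds have the same atoms and bonds and differ only in configuration as drawn: 2 of 4 stereo elements differ; a stereocentre at a saturated ring carbon is drawn S in compound 1 and R in compound 4; a stereocentre at a saturated ring carbon is drawn R in compound 1 and S in compound 4). Since the step that inverts one centre, the step that inverts three and the step that inverts all four each produced no change beyond the scatter in this assay, a change of two centres is expected to behave the same way. Compound 4 is accordingly estimated to give 6%, between 0% and 18%, which means an expected step of a number 1.8 percentage points higher from compound 1 to compound 4 (within the scatter).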

Compound 4, a percentage reported as inhibition, at one concentration (the size of the read-out at that concentration, not a potency): 4.4%
The estimate for compound 4 lay 1.6 percentage points above the measured number, within the range that was stated.
By their numbers in this assay, from the lowest: compounds 3, 1, 4 and 2 (each within the scatter of the next).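

In this assay, going by these compounds alone, the inversion of two ring stereocentres fills the one gap left by the earlier steps, which had inverted one, three or all four centres, and it gives a number 0.2 percentage points higher from compound 1 to compound 4 (within the scatter), so this change also leaves the read-out inside the scatter: the fact that compounds 1 and 4 differ only in the configuration as drawn. The two further steps read the same way, with a number 1 percentage points higher from compound 3 to compound 4 (within the scatter) and a number 6.6 percentage points lower from compound 2 to compound 4 (within the scatter). Across the four stereoisomers shown, every listed step stays within the scatter, so no single centre or combination of centres can be picked out as mattering in this assay at the one concentration tested.

The compounds leave open whether these configurations would separate from one another at another concentration or against another enzyme, as a single percentage gives no potency. They also leave open whether a hydroxymethyl group or an amide in place of the carboxylic acid on the shared core would move the read-out beyond the scatter, and whether any configurational preference would then appear.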